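The compounds below may be only part of what the source reports. "The series", "measured", "known", "first", "only" and "open" are said of these compounds alone.

Of the compounds shown here, two on one shared core have been measured so far. In a functional assay on HCT-116 cells (Homo sapiens) for antiproliferative activity, with a stated time of 72 h (a lower number here means a stronger inhibitor, a higher number a weaker inhibitor), compound 1 (`Nc1ccc(-c2ccccc2)cc1NC(=O)c1ccc(CN2CCC3(CCCN3)CC2)cc1`) gives 118 nM and compound 2 (`Nc1ccc(-c2cccs2)cc1NC(=O)c1ccc(CN2CCC3(CCCN3)CC2)cc1`) gives 82 nM in the same test. These two values lie within the scatter of each other, so the numbers place compound 2 level with compound 1.

The next structure, compound 3 (`Nc1ccc(-c2ccccc2F)cc1NC(=O)c1ccc(CN2CCC3(CCCN3)CC2)cc1`), changes the group at the same position, with 2-fluorophenyl in place of thiophen-2-yl on an aromatic carbon. Among the compounds with values here, only one measured step bears on this change: swapping phenyl for thiophen-2-yl at that carbon gave a 1.4-fold lower number from compound 1 to compound 2 (0.16 log units; within the scatter) as its result. Compound 3 returns to a six-membered aromatic ring of carbon only, as in compound 1, but now with a fluorine on it. Within the data shown here, no measured compound shows what that fluorine does by itself. Among the measured compounds shown here, with only that small step as a guide, no shift beyond the scatter is expected in this assay here. The expected move (a 1.3-fold higher number from compound 2 to compound 3 (0.13 log units; within the scatter)) is an estimate that stays within the scatter. Compound 3 is therefore expected at 110 nM (estimated range 45 nM to 270 nM).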

Compound 3, half-maximal inhibitory concentration: 470 nM
Beside the measured number, compound 3's estimate is 4.3-fold (0.63 log units) below it, and the stated range ends below it.
By their numbers in this assay, from the lowest: compounds 2 and 1 (each within the scatter of the next); then compound 3.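

This position is less tolerant than the first two compounds suggested: replacing phenyl with thiophen-2-yl kept the values within the scatter, but in this assay putting fluoro in place of hydrogen on the phenyl ring gives a 4.0-fold higher number from compound 1 to compound 3 (0.60 log units; beyond the scatter) at this carbon. The change from thiophen-2-yl to 2-fluorophenyl gives a 5.7-fold higher number from compound 2 to compound 3 (0.76 log units; beyond the scatter) and so also moves the number beyond the scatter, which leaves 2-fluorophenyl standing apart from the other two groups at this carbon. Even one added fluoro on the attached ring can therefore weaken the result in this series, and no supporting measurement is available to explain the shift.

The compounds shown do not tell whether this loss belongs to fluorine itself or to any group at that spot on the ring, a question that a chloro or methyl group in the same place, or a fluoro group elsewhere on the ring, would address. They also leave open how other five- and six-membered aromatic rings, such as furan or pyridine, would behave at this carbon.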